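Two fluoromethylphenyl amides and an estimate for a third

This account rests on a few compounds, and the source may have more. Where it says the series, first, only, none or still open, it means among the compounds named here.

Compound 1, `Cc1ccccc1N(C)C(=O)c1ccc(-c2ccc(OS(N)(=O)=O)cc2F)o1`, gives 16 nM in an assay on T47D cells for inhibition of Steryl-sulfatase (Homo sapiens), read by HPLC, with a stated time of 24 h; a lower number here means a stronger inhibitor, a higher number a weaker inhibitor.
Compound 2, `Cc1cccc(F)c1N(C)C(=O)c1ccc(-c2ccc(OS(N)(=O)=O)cc2)o1`, shows "nd" (no result reported) in this assay, that is, no reported result.

Compound 2 stands nowhere on the numbers: in this assay it has no single value, so it offers no reference point of its own. For the measured compounds named here, the only measured number in the set comes from compound 1, and it is 16 nM. Compound 3, `Cc1cc(F)ccc1N(C)C(=O)c1ccc(-c2ccc(OS(N)(=O)=O)cc2)o1`, differs from compound 2 in one place: 4-fluoro-2-methylphenyl in place of 2-fluoro-6-methylphenyl on an amide-type nitrogen. Going by the values given here, no step between two measured compounds exists here, so the size and direction of this change cannot be read from any measured pair; a shift of no more than the usual scatter in this assay is expected, in either direction. Because compound 1 gives 16 nM with the shared core, a number near it is expected for compound 3, about 20 nM, within a range from 6 nM to 70 nM.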

Compound 3, half-maximal inhibitory concentration: 15 nM
Estimate against measurement, compound 3: 1.3-fold (0.12 log units) above; the range from low to high includes it.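

No new step can be read: compound 2 has no number in this assay to set against compound 3. The compounds shown leave open what swapping 2-fluoro-6-methylphenyl for 4-fluoro-2-methylphenyl does to potency. Nothing shown offers an explanation for the result of compound 3.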